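Swapping the benzyl aryl for a pyrrolidine amide

A few compounds are considered here, and "the series" means these few. Any claim that something is new, unique, unknown or untested is made for them only; others in the source may bear on it.

Measured so far in an ADME assay on MT4 cells (Homo sapiens) for cytotoxicity, read by MTT assay, with a stated time of 5 days; on this read-out lower numbers stand for higher toxicity in this test and higher numbers for lower toxicity in this test:
Compound 1 `CC(=O)Cn1cc(CNC(=O)c2cnc(Nc3ccc(C#N)cc3)cc2Oc2c(C)cc(C)cc2C)nn1`: 19400 nM
Compound 2 `Cc1cc(C)c(Oc2cc(Nc3ccc(C#N)cc3)ncc2C(=O)NCc2cn(Cc3cccc(Cl)c3)nn2)c(C)c1`: 187000 nM
Compound 3 `Cc1cc(C)c(Oc2cc(Nc3ccc(C#N)cc3)ncc2C(=O)NCc2cn(Cc3ccc([N+](=O)[O-])cc3)nn2)c(C)c1`: >= 139000 nM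

Compound 2 stands at the highest of the two plain numbers, with compound 1 nearest at a 9.6-fold higher number from compound 1 to compound 2 (0.98 log units; beyond the scatter). Compound 3 gives only a limit of the assay, not a number (the limit of >= 139000 nM in this assay, at which 1 of the 3 values shown sits). Compound 4 `Cc1cc(C)c(Oc2cc(Nc3ccc(C#N)cc3)ncc2C(=O)NCc2cn(CC(=O)N3CCCC3)nn2)c(C)c1` differs from compound 2 in one place: (pyrrolidin-1-yl)carbonyl in place of 3-chlorophenyl on a saturated chain carbon bound to an aromatic nitrogen. For the measured compounds named here, two measured steps bear on the change at this position. Replacing acetyl on the saturated chain carbon bound to the aromatic nitrogen by an aryl group gave a 9.6-fold higher number from compound 1 to compound 2 (0.98 log units; beyond the scatter) and an at least 7.1-fold higher number from compound 1 to compound 3 (0.85 log units; beyond the scatter), while the aryl-to-aryl exchange remains unreadable: a step that the limit leaves unreadable from compound 2 to compound 3. Compound 4 puts a carbonyl-bearing group back in place of the aryl, so the step is expected to run in the opposite direction to those two, toward compound 1, as a 3.1-fold lower number from compound 2 to compound 4 (0.49 log units; beyond the scatter). Compound 4 is therefore estimated at 60000 nM, between 15000 nM and 200000 nM.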

Compound 4, half-maximal cytotoxic concentration: 58100 nM
Compound 4: the middle estimate sits 1.0-fold (0.01 log units) above what was measured; the range from low to high includes it.
By their numbers in this assay, from the lowest: compound 1; then compound 4; then compound 2.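

With the carbonyl kept on the saturated chain carbon bound to an aromatic nitrogen, the group on that carbonyl also matters in this assay: pyrrolidin-1-yl in place of methyl gives a 3.0-fold higher number from compound 1 to compound 4 (0.48 log units; beyond the scatter). A carbonyl-bearing group at this position therefore need not sit as low as the acetyl of compound 1, although replacing the aryl groups still gives a 3.2-fold lower number from compound 2 to compound 4 (0.51 log units; beyond the scatter) and an at least 2.3-fold lower number from compound 3 to compound 4 (0.37 log units; beyond the scatter). Compound 3 stands at a limit of the assay, not a number: the limit of >= 139000 nM in this assay, at which 1 of the 4 values shown sits.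

The compounds shown leave open whether this gain follows the pyrrolidine ring or any amide at that carbonyl, which a morpholine or a diethylamino group there would test. They also leave open how a benzyl group carrying an amine or a carboxylic acid would compare with compound 2.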